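The source may report more compounds than this note shows. Statements on the series, on what has been measured and on what is new or still open speak of the compounds shown alone.

Three compounds have been measured in a functional assay on T47D cells (Homo sapiens) for cytotoxicity, read by CCK-8 assay and cell counting, with a stated time of 2 days; a lower number here means a stronger inhibitor, a higher number a weaker inhibitor:

Compound 1 `Oc1ccc(-c2cc(-c3ccc(Cl)cc3)nc(-c3cccnc3)c2)cc1`: 29300 nM
Compound 2 `Oc1ccc(-c2cc(-c3cccnc3)nc(-c3cccc(Cl)c3)c2)cc1`: 25700 nM
Compound 3 `Oc1ccc(-c2cc(-c3ccc(Cl)cc3)nc(-c3ccco3)c2)cc1`: 6260 nM

Compound 2 differs from compound 1 by 3-chlorophenyl in place of 4-chlorophenyl on an aromatic carbon, and this gave a 1.1-fold lower number from compound 1 to compound 2 (0.06 log units; within the scatter). Compound 3 differs from compound 1 by furan-2-yl in place of pyridin-3-yl on an aromatic carbon, which gave a 4.7-fold lower number from compound 1 to compound 3 (0.67 log units; beyond the scatter). Compound 4 `Oc1ccc(-c2cc(-c3cccc(Cl)c3)nc(-c3ccco3)c2)cc1` has not yet been measured; it differs from compound 3 by 3-chlorophenyl in place of 4-chlorophenyl on an aromatic carbon. This is the same kind of change as that from compound 1 to compound 2, seen twice among these compounds, but the surroundings differ: the place is meta to a pyridin-3-yl group in the first pair and meta to a furan-2-yl group in the second. Because the earlier step was a 1.1-fold lower number from compound 1 to compound 2 (0.06 log units; within the scatter), a similarly small step is expected here, a 1.1-fold lower number from compound 3 to compound 4 (0.03 log units; within the scatter). Compound 4 is estimated at 5800 nM, within 3000 nM to 11000 nM.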

Compound 4, half-maximal inhibitory concentration: 5220 nM
For compound 4 the middle estimate is 1.1-fold (0.05 log units) above the measured one, and the stated range covers the measured number.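

Placing 3-chlorophenyl where 4-chlorophenyl stood gave a 1.2-fold lower number from compound 3 to compound 4 (0.08 log units; within the scatter), a step that stays within the scatter on this core as on the earlier one: the same change on two cores in this assay, a 1.1-fold lower number (0.06 log units; within the scatter) from compound 1 to compound 2 and a 1.2-fold lower number (0.08 log units; within the scatter) from compound 3 to compound 4, 1.1-fold (0.02 log units) apart, within the scatter of two such steps Furan-2-yl in place of pyridin-3-yl gave a 4.9-fold lower number from compound 2 to compound 4 (0.69 log units; beyond the scatter), and this clear gain carried over from one chlorophenyl isomer to the other: the same change on two cores in this assay, a 4.7-fold lower number (0.67 log units; beyond the scatter) from compound 1 to compound 3 and a 4.9-fold lower number (0.69 log units; beyond the scatter) from compound 2 to compound 4, 1.1-fold (0.02 log units) apart, within the scatter of two such steps In this assay, the two changes therefore look independent of each other across these four compounds, but this does not show that they would stay so with other groups or on other cores.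

Going by these compounds, what remains open is whether the gain is specific to furan-2-yl or extends to a ring such as thiophen-2-yl. Also open, on these data alone, is what an amine or a carboxylic acid in place of the chlorine would do.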